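Notes on the chloro-to-hydrogen step, compound 3 to compound 4

The source may hold more compounds than are shown below. What is called first, only, known or untested is meant among the compounds shown, and "the series" means these compounds.

Measured so far in a functional assay on A549 cells (Homo sapiens) for antiproliferative activity, read by MTT assay, with a stated time of 72 h; a higher number here means a weaker inhibitor, a lower number a stronger inhibitor:
compound 1 `COc1cc(CCc2cccc(F)c2)cc(OC)c1O` gives 2240 nM
compound 2 `COc1ccccc1CCc1cc(OC)c(O)c(OC)c1` gives 1740 nM
compound 3 `COc1cc(CCc2ccccc2Cl)cc(OC)c1O` gives 2130 nM

All three numbers sit close together. In this assay compound 3 stands second highest of the three, nearest compound 1 and furthest from compound 2, but both gaps are within the scatter, so no order among the three can be read from them. For the measured compounds named here, the only single-point step measured, a 1.2-fold higher number from compound 2 to compound 3 (0.09 log units; within the scatter), chloro in place of methoxy on an aromatic carbon, also stays within the scatter.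

Compound 4 `COc1cc(CCc2ccccc2)cc(OC)c1O` is not yet measured. It differs from compound 3 by hydrogen in place of chloro on an aromatic carbon. Going by the values given here, no measured pair exchanges chloro for hydrogen, so no step bears directly on this change. What can be said is that the measured substituent exchange at the same kind of position, a 1.2-fold higher number from compound 2 to compound 3 (0.09 log units; within the scatter), moved the number by less than the scatter, and that compounds 1, 2 and 3 carry different groups on that ring yet give numbers within the scatter of one another.

On that basis the expected step of a 1.1-fold higher number from compound 3 to compound 4 (0.05 log units; within the scatter) is none beyond the scatter. Compound 4 is therefore estimated at 2400 nM, with a range from 1200 nM to 5000 nM.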

Compound 4, half-maximal inhibitory concentration: 10900 nM
Beside the measured number, compound 4's estimate is 4.5-fold (0.66 log units) below it, and the stated range ends below it.
By their numbers in this assay, from the lowest: compounds 2, 3 and 1 (each within the scatter of the next); then compound 4.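

In this assay the earlier exchanges among substituents on this ring stayed within the scatter, so they gave no sign that the ring carbon mattered, whereas removing the group altogether gives a clear loss: chloro to hydrogen on the aromatic carbon ortho to a large group is (a 5.1-fold higher number from compound 3 to compound 4 (0.71 log units; beyond the scatter)), methoxy to hydrogen is (a 6.3-fold higher number from compound 2 to compound 4 (0.80 log units; beyond the scatter)) and fluoro to hydrogen is (a 4.9-fold higher number from compound 1 to compound 4 (0.69 log units; beyond the scatter)). All three steps lie beyond the scatter and point the same way, with no compound shown going against them, so compound 4 is the weakest of the four, and in this small set the presence of chloro, methoxy or fluoro counts for more than which of the three is present. No measurement shown here offers an explanation for this loss.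

Still open is whether the requirement extends to very different groups on this ring, such as an amine, a carboxylic acid or a longer chain like butoxy, or holds only for the three groups shown. Going by these compounds, it is also open whether the same loss on going to hydrogen would appear with the other parts of the shared core changed.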